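A few compounds are considered here, and "the series" means these few. Any claim that something is new, unique, unknown or untested is made for them only; others in the source may bear on it.

Measured so far in a toxicity assay on Vero cells (Chlorocebus sabaeus) for inhibition; on this read-out lower numbers stand for an effect already at smaller amounts and higher numbers for an effect only at larger amounts of compound:
Compound 1 `COc1cccc(NC(=O)c2nnn(Cc3cc(C)on3)c2N)c1` gives > 50100 nM, a limit of the assay.
Compound 2 `COc1cccc(NC(=O)c2nnn(Cc3ccc(-n4cccn4)cc3)c2N)c1` gives > 50100 nM, also a limit of the assay.
Compound 3 `COc1cccc(NC(=O)c2nnn(CC3CCN(C(C)=O)CC3)c2N)c1` gives > 50100 nM, again a limit of the assay.

All three values therefore sit at the limit of > 50100 nM in this assay, at which 3 of the 3 values shown sit, rather than being numbers, and compound 2 stands at that limit, indistinguishable from the other two. Within the data shown here, the only step between measured compounds, a step that the two limits leave unreadable from compound 1 to compound 3, cannot be read in size. Compound 4 `COc1cccc(NC(=O)c2nnn(Cc3ccc(C(C)C)cc3)c2N)c1` carries isopropyl in place of 1H-pyrazol-1-yl on an aromatic carbon. Among the measured compounds shown here, no measured step bears on such a change, and the three limits give no trend to lean on. The step that the limit leaves unreadable from compound 2 to compound 4 is expected to be none beyond the scatter, with compound 4 most likely again reported only as a limit. The estimate for compound 4 in this assay is 60000 nM, in the range 30000 nM to 150000 nM.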

Compound 4, half-maximal effective concentration: > 50100 nM
Compound 4: only a limit was reported; the forecaster's own chance of this, stated with the estimate: 85%; the middle value does not contradict the limit.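

In this assay compound 4 gives > 50100 nM, a limit and not a number. The steps to compound 4 from compound 1, compound 2 and compound 3 therefore cannot be read: the limit of > 50100 nM in this assay, at which 4 of the 4 values shown sit.

The compounds shown leave open whether these four truly differ in this assay, and which change to the shared core would give a readable number.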